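This account rests on a few compounds, and the source may have more. Where it says the series, first, only, none or still open, it means among the compounds named here.

Measured compounds:
compound 1 `Nc1ncnc2c1c(-c1cc(C3CC3)on1)nn2C1CCOCC1`, 32900 nM
compound 2 `CC(C)c1cc(-c2nn(C(C)C)c3ncnc(N)c23)no1`, 23700 nM
compound 3 `CCCCCCCn1nc(-c2cc(C3CC3)on2)c2c(N)ncnc21`, 31600 nM

All three share one core and differ in the group on an aromatic nitrogen. In an ADME assay on Nthy-ori 3-1 cells (Homo sapiens) for cytotoxicity, read by MTT assay, with a stated time of 10 days (on this read-out higher numbers stand for weaker inhibition of growth and lower numbers for stronger inhibition of growth), compound 3 gives 31600 nM, the second highest of the three numbers; its nearest neighbour is compound 1 with 32900 nM and its furthest is compound 2 with 23700 nM, and both of those gaps fall within the usual scatter of repeated measurements.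

The step to compound 4 `Cn1nc(-c2cc(C3CC3)on2)c2c(N)ncnc21` is hydrogen in place of hexyl on a saturated chain carbon bound to an aromatic nitrogen. Going by the values given here, one measured step bears on it: a 1.0-fold lower number from compound 1 to compound 3 (0.02 log units; within the scatter), a change at the same aromatic nitrogen that left the value unmoved beyond the scatter. Compound 2, carrying propan-2-yl at that position, also gives a value within the scatter of compound 3. Three different groups at this position have therefore given numbers that cannot be told apart, so shortening heptyl to methyl is expected to leave this assay where it is.

Compound 4 is accordingly estimated to give 30000 nM, within 12000 nM to 75000 nM, an expected step of a 1.1-fold lower number from compound 3 to compound 4 (0.02 log units; within the scatter).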

Compound 4, concentration for 50% growth inhibition: 28700 nM
The estimate for compound 4 lay 1.0-fold (0.02 log units) above the measured number; the measured number falls inside the stated range.
By their numbers in this assay, from the lowest: compounds 2, 4, 3 and 1 (each within the scatter of the next).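

In this assay, cutting the chain from heptyl to methyl, which removes a hexyl of 6 heavy atoms, gives a small step that stays within the usual scatter (a 1.1-fold lower number from compound 3 to compound 4 (0.04 log units; within the scatter)). The earlier compounds had shown only larger groups on this aromatic nitrogen, so this is the first sign that a single carbon there reads the same as a long chain, and the comparison with the ring-bearing compound agrees (a 1.1-fold lower number from compound 1 to compound 4 (0.06 log units; within the scatter)). Methyl, heptyl and oxan-4-yl therefore cannot be told apart at this position in this cell assay, and no measurement at hand offers a reason for that.

As far as these compounds go, the groups compared here are a short chain, a long chain and a saturated ring, so it remains open whether an amine or a carboxylic acid at the end of the chain, or a phenyl ring on the same nitrogen, would also leave the number inside the scatter. From the compounds shown here alone, it is equally open what a plain hydrogen on that aromatic nitrogen would give.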